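Phenyl in place of chloromethyl on the shared core

A few compounds are considered here, and "the series" means these few. Any claim that something is new, unique, unknown or untested is made for them only; others in the source may bear on it.

In an ADME assay on H9c2 cells (Rattus norvegicus) for cytotoxicity, read by resazurin assay, with a stated time of 72 h (a lower number here means that less compound is tolerated, a higher number that more compound is tolerated), compound 1 (`C/C(=N\Nc1nc(C)cs1)c1ccc(Cl)c(Cl)c1`) gives 26100 nM. Compound 2 (`C/C(=N\Nc1nc(CCl)cs1)c1ccc(Cl)c(Cl)c1`) reaches only a limit, > 50000 nM. Compound 3 (`C/C(=N\Nc1nc(-c2ccccc2)cs1)c1ccc(Cl)c(Cl)c1`) carries phenyl in place of chloromethyl on an aromatic carbon. For the measured compounds named here, the only measured step bearing on this, an at least 1.9-fold higher number from compound 1 to compound 2 (0.28 log units; that floor lies within the scatter), alters the chain and does not bring in a ring, so it gives weak guidance. Going by the values given here, compound 1 at 26100 nM is the only firm number, so a modest fall in this assay is expected. The expected step is an at least 2.0-fold lower number from compound 2 to compound 3 (0.30 log units; that floor lies within the scatter). Compound 3 is estimated at 25000 nM, with an expected range of 8000 nM to 50000 nM.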

Compound 3, half-maximal cytotoxic concentration: > 50000 nM
Compound 3 was reported as a limit; the forecaster's own chance of this, stated with the estimate: 30%; middle value at least 2.0-fold (0.30 log units) from the limit.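

Compound 3 shows that a ring at this position, next to the ring nitrogen, goes with a limit in this assay just as the chloromethyl chain does, so that limit is not tied to the chlorine. Phenyl in place of methyl gives an at least 1.9-fold higher number from compound 1 to compound 3 (0.28 log units; that floor lies within the scatter) and so stays a floor, not a measured size. The step between compound 2 and compound 3 cannot be read because both are only limits: the limit of > 50000 nM in this assay, at which 2 of the 3 values shown sit.

On these data alone, how far either compound lies past that limit stays open. So does whether an amine or a carboxylic acid on this carbon would give a firm number.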